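Piperidine to amine on the shared core

This account rests on a few compounds, and the source may have more. Where it says the series, first, only, none or still open, it means among the compounds named here.

Measured compounds:
compound 1 `C=CC(=O)Nc1cc(N)nc(Sc2c(OC)nc(N3CCN(C)CC3)nc2OC)n1` — 2000 nM
compound 2 `C=CC(=O)Nc1cc(N)nc(Sc2c(OC)nc(N3CCCCC3)nc2OC)n1` — 5000 nM

For the measured compounds named here, in a functional assay on SK-BR-3 cells (Homo sapiens) for activation, read by Western blot (a higher number here means a weaker inhibitor, a lower number a stronger inhibitor), compound 2 gives the highest of the two numbers so far, its nearest neighbour being compound 1, whose a 2.5-fold higher number from compound 1 to compound 2 (0.40 log units; beyond the scatter) is the only step within the set and is of modest size. Compound 3 `C=CC(=O)Nc1cc(N)nc(Sc2c(OC)nc(N)nc2OC)n1` differs from compound 2 by a single change: amino in place of piperidin-1-yl on an aromatic carbon. Going by the values given here, no measured pair shows a ring group giving way to a single-atom group at this position, so the one step on record bears on compound 3 only indirectly, as a sign that a change of the group on this aromatic carbon has moved this assay by a modest amount in the past. A comparable modest shift is therefore expected here, in either direction, with no strong reason to favour one side. Compound 3 is estimated at 4000 nM, within a range of 1500 nM to 12000 nM, which corresponds to an expected 1.3-fold lower number from compound 2 to compound 3 (0.10 log units; within the scatter).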

Compound 3, half-maximal inhibitory concentration: 7500 nM
Beside the measured number, compound 3's estimate is 1.9-fold (0.27 log units) below it; measured number inside the range.
By their numbers in this assay, from the lowest: compound 1; then compounds 2 and 3 (each within the scatter of the next).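

In this assay, amino in place of piperidin-1-yl on this aromatic carbon leaves the result within the scatter (a 1.5-fold higher number from compound 2 to compound 3 (0.18 log units; within the scatter)), so compounds 2 and 3 cannot be told apart, even though amino brings no ring and far fewer heavy atoms to the position. The same amino set against 4-methylpiperazin-1-yl gives a step beyond the scatter (a 3.8-fold higher number from compound 1 to compound 3 (0.57 log units; beyond the scatter)), and with the step to piperidin-1-yl (a 2.5-fold higher number from compound 1 to compound 2 (0.40 log units; beyond the scatter)) this leaves compound 1 as the only one of the three separated from both others, with the lowest number. Among these three groups, then, the ring alone does not separate the compounds, and nothing measured here accounts for the position of compound 1.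

Going by these compounds, whether the step from compound 1 depends on the ring nitrogen carrying the methyl group remains open, and piperazin-1-yl, morpholin-4-yl or 4-hydroxypiperidin-1-yl at this position would bear on that. Also open, on these data alone, is whether an open-chain group such as dimethylamino or a longer aminoalkyl chain would behave like amino or like 4-methylpiperazin-1-yl.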